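Bromo to hydroxy on the amide chain of two chromenes

The compounds below may be only part of what the source reports. "The series", "measured", "known", "first", "only" and "open" are said of these compounds alone.

Measured compounds:
compound 1 `COc1ccc(C(=O)c2ccc(OC)c3c2C=CC(C)(C)O3)c(NC(=O)CBr)c1`: 3290 nM
compound 2 `COc1ccc(C(=O)c2ccc3c(c2)C=CC(C)(C)O3)c(NC(=O)CBr)c1`: 2880 nM
compound 3 `COc1ccc(C(=O)c2ccc(OC)c3c2C=CC(C)(C)O3)c(NC(=O)CO)c1`: 940 nM

All three numbers come from a functional assay on MCF7 cells (Homo sapiens) for antiproliferative activity, read by MTT assay, with a stated time of 48 h; on this read-out higher numbers stand for weaker inhibition and lower numbers for stronger inhibition. Compound 1 and compound 2 differ in their cores; the difference between the two cores is not broken down here, and in this assay the values of compound 1 and compound 2 sit within the scatter of each other. On the core of compound 1 the change hydroxy in place of bromo on a saturated chain carbon bound to a carbonyl carbon gave a 3.5-fold lower number from compound 1 to compound 3 (0.54 log units; beyond the scatter).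

Compound 4 `COc1ccc(C(=O)c2ccc3c(c2)C=CC(C)(C)O3)c(NC(=O)CO)c1` carries the same change on the core of compound 2: hydroxy in place of bromo on a saturated chain carbon bound to a carbonyl carbon. For the measured compounds named here, only one measured instance of this change exists, so the expectation rests on a single precedent. The step from compound 2 to compound 4 is expected to be of similar size, a 3.4-fold lower number from compound 2 to compound 4 (0.53 log units; beyond the scatter), resting on a 3.5-fold lower number from compound 1 to compound 3 (0.54 log units; beyond the scatter) seen on a core whose value lies close to that of compound 2. Compound 4 is therefore estimated at 850 nM, with a likely range from 400 nM to 1900 nM.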

Compound 4, half-maximal inhibitory concentration: 200 nM
Beside the measured number, compound 4's estimate is 4.3-fold (0.63 log units) above it; the measured number lies below the stated range.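

In this assay, hydroxy in place of bromo on a saturated chain carbon bound to a carbonyl carbon gave a 14-fold lower number from compound 2 to compound 4 (1.16 log units; beyond the scatter), so the number fell on both cores. The direction carried over from one core to the other, but the size did not, even though compound 1 and compound 2 sit within the scatter of each other: the same change on two cores in this assay, a 3.5-fold lower number (0.54 log units; beyond the scatter) from compound 1 to compound 3 and a 14-fold lower number (1.16 log units; beyond the scatter) from compound 2 to compound 4, 4.1-fold (0.61 log units) apart, beyond the scatter of two such steps Two pairs show that the size of this step can depend on the core; they do not show why, or how the step would run on a further core.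

The compounds shown leave open how an amine or a carboxylic acid would compare with hydroxy at this chain carbon. They also leave open whether a longer chain carrying the hydroxy would show the same dependence on the core.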